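Swapping the aryl on the ring nitrogen toward a single chlorine

The source may report more compounds than this note shows. Statements on the series, on what has been measured and on what is new or still open speak of the compounds shown alone.

Compounds measured so far:
compound 1 `O=C1CC(c2nc(-c3cccc(Cl)c3)no2)CN1c1ccc(Cl)c(Cl)c1` with 460 nM
compound 2 `Cc1ccccc1N1CC(c2nc(-c3cccc(Cl)c3)no2)CC1=O` with > 10000 nM

Both compounds share a five-membered lactam core carrying an oxadiazole with a 3-chlorophenyl group; they differ only in the aryl ring on the amide-type nitrogen. In an in vitro functional assay on HEK293-A cells for positive allosteric modulation of metabotropic glutamate receptor 5 (Homo sapiens), read by FLIPR and calcium flux (on this read-out lower numbers stand for an effect already at smaller amounts and higher numbers for an effect only at larger amounts of compound), compound 1 gives 460 nM. For compound 2 the value is a limit of the assay, not a number: compound 2 sits at the limit of > 10000 nM in this assay, at which 1 of the 2 values shown sits, so it stands at the weak end of everything measured here. For the measured compounds named here, the only measured step is an at least 21-fold higher number from compound 1 to compound 2 (1.33 log units; beyond the scatter), and it shows that trading 3,4-dichlorophenyl for 2-methylphenyl removes most of the effect.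

Compound 3 `O=C1CC(c2nc(-c3cccc(Cl)c3)no2)CN1c1cccc(Cl)c1` has not been measured. The change from compound 2 is 3-chlorophenyl in place of 2-methylphenyl on an amide-type nitrogen in a ring. This brings back one of the two chlorines of compound 1 while removing the methyl. Going by the values given here, only the step from compound 1 to compound 2 bears on it, and it was large. In this assay compound 3 is therefore expected to recover part of that loss, a step of an at least 6.6-fold lower number from compound 2 to compound 3 (0.82 log units; beyond the scatter) toward the stronger side. The estimate for compound 3 is 1500 nM, with a range from 400 nM to 8000 nM.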

Compound 3, half-maximal effective concentration: > 10000 nM
Compound 3: no number, only a limit (the forecaster's own chance of this, stated with the estimate: 25%); middle value at least 6.6-fold (0.82 log units) away from the limit.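

Taking away a single chlorine, with hydrogen in place of chloro on an aromatic carbon, gives an at least 21-fold higher number from compound 1 to compound 3 (1.33 log units; beyond the scatter) in this assay. The earlier step swapped one aryl group for another that differed in more than one way, whereas this one shows that at this amide-type nitrogen in a ring, the 3,4-dichlorophenyl group of compound 1 cannot be cut back to 3-chlorophenyl without losing most of the effect. The steps that would rank 3-chlorophenyl against 2-methylphenyl cannot be read, as compound 2 and compound 3 both end at the same limit and so only compound 1 of the three gives a number: the limit of > 10000 nM in this assay, at which 2 of the 3 values shown sit.

As far as these compounds go, what remains open is whether the other chlorine of compound 1 could carry the effect alone, as a 4-chlorophenyl group on the same nitrogen would show. From the compounds shown here alone, it is also open whether the two chlorines can be replaced by other groups, as in a 3,4-dimethylphenyl or 3,4-difluorophenyl group, or whether this position needs chlorine itself.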